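The source may hold more compounds than are shown below. What is called first, only, known or untested is meant among the compounds shown, and "the series" means these compounds.

Working notes on the series in a functional assay on BSC-1 cells (Cercopithecidae) for cytotoxicity; a lower number here means a stronger inhibitor, a higher number a weaker inhibitor.

Compound 1 `CSc1nc(N)c2ccn(COCCO)c2n1` carries a methylsulfanyl group on the shared core. In this assay compound 1 is recorded only as a limit, > 100000 nM. Compound 2 `Nc1ncnc2c1ccn2COCCO` has hydrogen in that place. In this assay compound 2 is likewise reported as a limit, > 100000 nM. Compound 3 `Nc1nc(O)nc2c1ccn2COCCO` has hydroxy in that place. In this assay compound 3 is again given as a limit, > 100000 nM. Compound 3 therefore stands at the same limit as the other two, and none of the three can be ordered against another.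

The steps within the measured set are a step that the two limits leave unreadable from compound 1 to compound 2, a step that the two limits leave unreadable from compound 1 to compound 3 and a step that the two limits leave unreadable from compound 2 to compound 3; their sizes are not readable because all three values sit at the limit of > 100000 nM in this assay, at which 3 of the 3 values shown sit.

Compound 4 `Nc1nc(N)c2ccn(COCCO)c2n1` is the next member. The change from compound 3 is amino in place of hydroxy on an aromatic carbon. For the measured compounds named here, no measured step bears readably on this change; the three measured steps only show that every variation at this aromatic carbon so far has stayed at the limit. The change is therefore expected to give a number no higher from compound 3 to compound 4 (the limit leaves the size open), no readable movement. For compound 4 the estimate in this assay is 100000 nM, within 30000 nM to 300000 nM, most likely reported once more as a limit.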

Compound 4, half-maximal inhibitory concentration: > 100000 nM
Compound 4 was reported as a limit (the forecaster's own chance of this, stated with the estimate: 85%); the middle value lies on the limit itself.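

No step linking compound 4 with compound 1, compound 2 or compound 3 can be read in this assay, because all four values are limits: the limit of > 100000 nM in this assay, at which 4 of the 4 values shown sit.

The compounds shown leave open how far apart these four lie, and whether any group on this aromatic carbon changes the read-out.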